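A few compounds are considered here, and "the series" means these few. Any claim that something is new, unique, unknown or untested is made for them only; others in the source may bear on it.

Of the compounds shown here, three of one shared core have been tested in a functional assay on A549 cells (Homo sapiens) for inhibition, read by CCK-8 assay, with a stated time of 72 h, tested at 1 uM; on this read-out higher numbers stand for more inhibition of growth at the one concentration tested and lower numbers for less inhibition of growth. Compound 1 `Cc1cccc(NC(=O)C2(C(=O)Nc3ccc(Nc4ncc5cc(C(=O)N(C)C)n(C6CCCC6)c5n4)cc3)CC2)c1` gives 35.2%. Compound 3 `Cc1ccc(NC(=O)C2(C(=O)Nc3ccc(Nc4ncc5cc(C(=O)N(C)C)n(C6CCCC6)c5n4)cc3)CC2)cc1` gives 40.2%, and the step of a number 5 percentage points higher from compound 1 to compound 3 (within the scatter) stays within the scatter. Compound 2 `COc1ccc(NC(=O)C2(C(=O)Nc3ccc(Nc4ncc5cc(C(=O)N(C)C)n(C6CCCC6)c5n4)cc3)CC2)cc1` gives 74.4%, the highest of the three numbers: the step of a number 39.2 percentage points higher from compound 1 to compound 2 (beyond the scatter) is beyond the scatter, and so is the step of a number 34.2 percentage points lower from compound 2 to compound 3 (beyond the scatter).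

Compound 4 `CN(C)C(=O)c1cc2cnc(Nc3ccc(NC(=O)C4(C(=O)Nc5ccc(C(F)(F)F)cc5)CC4)cc3)nc2n1C1CCCC1` has not yet been measured. It differs from compound 2 in one place: trifluoromethyl in place of methoxy on an aromatic carbon. Among the compounds with values here, the one measured step that bears on this change is the step of a number 34.2 percentage points lower from compound 2 to compound 3 (beyond the scatter), where the methoxy of compound 2 gave way to a methyl and the number fell by a large amount. Within the data shown here, no measured compound carries a trifluoromethyl, so how that group behaves here is unknown; the only guide is that losing the methoxy cost a lot. On that basis a fall in this assay from compound 2 to compound 4 is expected, of a size comparable to the step of a number 34.2 percentage points lower from compound 2 to compound 3 (beyond the scatter) but with wide uncertainty.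

The estimated step is a number 29.4 percentage points lower from compound 2 to compound 4 (beyond the scatter). Compound 4 is therefore expected to give about 45%, within a range from 22% to 70%.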

Compound 4, percent growth inhibition at one concentration: -25.3%
The estimate for compound 4 lay 70.3 percentage points above the measured number, and the stated range ends above it.
By their numbers in this assay, from the lowest: compound 4; then compounds 1 and 3 (each within the scatter of the next); then compound 2.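

In this assay, within the data shown here, the group at this place on the phenyl ring, para to a large group, matters far more than the earlier compounds could show: trifluoromethyl in place of methoxy gives a number 99.7 percentage points lower from compound 2 to compound 4 (beyond the scatter), and compound 4 at -25.3% is the only one of the four with a number below zero. The loss is not limited to the comparison with methoxy, as trifluoromethyl in place of methyl gives a number 65.5 percentage points lower from compound 3 to compound 4 (beyond the scatter) and the 4-(trifluoromethyl)phenyl group in place of 3-methylphenyl gives a number 60.5 percentage points lower from compound 1 to compound 4 (beyond the scatter), so the replacement leaves compound 4 well under all three earlier compounds. Nothing measured here about these groups accounts for this order.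

The compounds shown leave open whether an amine, a hydroxyl, a chlorine or a longer ether chain such as ethoxy at this place would match methoxy or fall towards trifluoromethyl. With only one concentration in this read-out, they also leave open how these compounds would compare across a range of concentrations.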